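This account rests on a few compounds, and the source may have more. Where it says the series, first, only, none or still open, it means among the compounds named here.

Of the compounds shown here, two have been measured in a functional assay on the whole organism (strain BALB/c) with Mus musculus as the target, in the writhing test, with a stated time of 1 h, at a dose of 50 mg/kg by the oral route; a higher number here means a stronger effect of the compound at the dose given, a lower number a weaker effect. Compound 1 `COc1ccc(Cc2n[nH]c(=S)n2N)cc1` gives 23.4% in this assay. Compound 2 `COc1ccc(Cc2nnc3n2N=C(c2ccc(Cl)cc2)CS3)cc1` gives 9.9% in this assay, the lowest of the two numbers and beyond the scatter below compound 1. Compound 3 `COc1ccc(Cc2nnc3n2N=C(c2ccc(F)cc2)CS3)cc1` differs from compound 2 by fluoro in place of chloro on an aromatic carbon. Within the data shown here, no measured pair shows this change, so no direction can be read from the numbers at hand. The step expected from this change, a number 2.1 percentage points higher from compound 2 to compound 3 (within the scatter), stays within the scatter, in either direction or none. Compound 3 is estimated at 12%, between 3% and 24%.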

Compound 3, a percentage reported as inhibition, in the whole organism at one dose (the size of the read-out at that dose, not a potency): 20.5%
Estimate against measurement, compound 3: 8.5 percentage points below; the measured number falls inside the stated range.
By their numbers in this assay, from the lowest: compound 2; then compounds 3 and 1 (each within the scatter of the next).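

Among these compounds, changing the halogen on this ring is not a silent swap: in this assay going from 4-chlorophenyl to 4-fluorophenyl gives a number 10.6 percentage points higher from compound 2 to compound 3 (beyond the scatter) and is the first step read between compounds that differ in one place. The group on this aromatic carbon can therefore shift the read-out at the dose given, although this modest step rests on a single pair. Nothing available on these compounds explains the shift. From the compounds shown here alone, whether a bromo group, a methyl group or an amine at this position would raise or lower the number remains open. So does whether the same swap would act alike on another core.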